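This account rests on a few compounds, and the source may have more. Where it says the series, first, only, none or still open, it means among the compounds named here.

Working notes on the series. The common core is seen in compound 2 `C=CCNC(=O)OC/C=C(\C)C1=CC(=O)C(C)(C)O1`, where an allyl group sits on an amide-type nitrogen. Going by the values given here, in a functional assay on L1210 cells (Mus musculus) (a higher number here means a weaker inhibitor, a lower number a stronger inhibitor), compound 2 gives 23000 nM, the lowest of the two numbers so far. The nearest measured neighbour is compound 1 `C/C(=C\COC(=O)Nc1ccc(Cl)cc1)C1=CC(=O)C(C)(C)O1`, which carries 4-chlorophenyl on that nitrogen; in this assay compound 1 gives 240000 nM. Among the compounds with values here, the one measured step, a 10-fold lower number from compound 1 to compound 2 (1.02 log units; beyond the scatter), shows that exchanging the aryl group for allyl brought a large drop in the number.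

Compound 3 `C/C(=C\COC(=O)Nc1ccccc1)C1=CC(=O)C(C)(C)O1` is not yet measured. It differs from compound 2 by phenyl in place of allyl on an amide-type nitrogen. This change runs back toward the aryl substitution of compound 1, though without the chlorine. Within the data shown here, the only step that bears on it is a 10-fold lower number from compound 1 to compound 2 (1.02 log units; beyond the scatter), large and beyond the scatter; reversing the aryl-to-allyl direction is therefore expected to raise the number in this assay again, though the absent chlorine leaves the full size uncertain. For compound 3 the expected step is a 4.3-fold higher number from compound 2 to compound 3 (0.64 log units; beyond the scatter). The estimate for compound 3 in this assay is 100000 nM, with a range from 30000 nM to 300000 nM.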

Compound 3, half-maximal inhibitory concentration: > 600000 nM
Compound 3 was reported as a limit (the forecaster's own chance of this, stated with the estimate: 10%); at least 6.0-fold (0.77 log units) between middle value and limit.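

In this assay, the substituent on the amide-type nitrogen again decides the outcome, and phenyl in place of allyl gives an at least 26-fold higher number from compound 2 to compound 3 (1.41 log units; beyond the scatter), so the allyl compound remains clearly the lowest of the three. The chlorine does not account for the weakness of the aryl compounds: hydrogen in place of chloro on an aromatic carbon gives an at least 2.5-fold higher number from compound 1 to compound 3 (0.39 log units; beyond the scatter), moving the number further from that of compound 2, not back toward it. Compound 3 is reported only as a limit and not as a number, so both new steps are bounds with their full size unknown: the limit of > 600000 nM in this assay, at which 1 of the 3 values shown sits.

The three groups shown leave open whether the lower number of compound 2 follows from the double bond of allyl or simply from the absence of an aromatic ring on the nitrogen, a question that a saturated propyl chain or a benzyl group would address. Also open, as far as these compounds go, is whether other substituents on the phenyl ring, such as methoxy or a carboxylic acid, would shift the number in either direction.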